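From a bare hydrazide to a furan-bearing thiosemicarbazone

This account rests on a few compounds, and the source may have more. Where it says the series, first, only, none or still open, it means among the compounds named here.

Compound 1 `CC1=CC[C@H](C(C)(C)NC(=S)NN)CC1` carries a free hydrazide end on its thiourea. In a functional assay on PC-3 cells (Homo sapiens) for inhibition, read by sulforhodamine B assay, with a stated time of 48 h (a lower number here means a stronger inhibitor of growth, a higher number a weaker inhibitor of growth), compound 1 gives only an assay limit, > 100000 nM, with no number. Among the compounds with values here, compound 2 `CC1=CC[C@H](C(C)(C)NC(=S)N/N=C/c2ccccc2Cl)CC1` gives 700 nM, and compound 3 `CC1=CC[C@H](C(C)(C)NC(=S)N/N=C/c2ccc(Cl)cc2)CC1` gives 1700 nM; the one measured step, a 2.4-fold higher number from compound 2 to compound 3 (0.39 log units; beyond the scatter), is modest. Compound 4 `CC1=CC[C@H](C(C)(C)NC(=S)N/N=C/c2ccco2)CC1` differs from compound 1 by a group of 7 heavy atoms (5 carbon, 1 nitrogen, 1 oxygen; one five-membered aromatic ring with 1 hetero atom) in place of one nitrogen atom, on an amide-type nitrogen. Within the data shown here, no measured step begins at compound 1, yet compound 2 and compound 3 show that an arylidene on this nitrogen pairs with a measurable number where compound 1 sits at the limit (the limit of > 100000 nM in this assay, at which 1 of the 3 values shown sits). A large drop is therefore expected, an at least 33-fold lower number from compound 1 to compound 4 (1.52 log units; beyond the scatter), though with a furan rather than a chlorophenyl the size is uncertain. Compound 4 is estimated at 3000 nM, between 800 nM and 12000 nM.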

Compound 4, concentration for total growth inhibition: 27200 nM
Estimate against measurement, compound 4: 9.1-fold (0.96 log units) below; measured number outside the range, above it.
By their numbers in this assay, from the lowest: compound 2; then compound 3; then compound 4. At a limit, above all of these: compound 1.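

Replacing the free amino end with the furan-bearing group gives an at least 3.6-fold lower number from compound 1 to compound 4 (0.56 log units; beyond the scatter), which is only a minimum since one end of the step is an assay limit: the limit of > 100000 nM in this assay, at which 1 of the 4 values shown sits. A group on this nitrogen does not settle the number alone, as the ring it carries matters: furan-2-yl gives a 16-fold higher number from compound 3 to compound 4 (1.20 log units; beyond the scatter) and a 39-fold higher number from compound 2 to compound 4 (1.59 log units; beyond the scatter). Both of these steps are large, whereas moving from 2-chlorophenyl to 4-chlorophenyl gave only a modest one.

Going by these compounds, it stays open whether the loss goes with the furan ring itself or with the absence of chlorine. An unsubstituted phenyl or a thiophene ring on the same carbon would help separate the two.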